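The source may report more compounds than this note shows. Statements on the series, on what has been measured and on what is new or still open speak of the compounds shown alone.

The series shares one core, seen in compound 1 `CC(c1ccc(-c2ccccc2)c(F)c1)c1nnc2n1N=C(c1ccc(Cl)cc1)CS2`, compound 2 `COc1ccc2cc(C(C)c3nnc4n3N=C(c3ccc(C(F)(F)F)cc3)CS4)ccc2c1` and compound 3 `CC(c1ccc(-c2ccccc2)c(F)c1)c1nnc2n1N=C(c1ccc(Cl)cc1Cl)CS2`. In a functional assay on HCT-116 cells (Homo sapiens) for inhibition, read by sulforhodamine B assay, with a stated time of 72 h (a lower number here means a stronger inhibitor, a higher number a weaker inhibitor), compound 1 gives 7800 nM, compound 2 gives 10800 nM and compound 3 gives 6900 nM. Compound 2 returns the highest of the three numbers, but its gaps to compound 1 and to compound 3 both lie within the scatter, so no ranking among the three is drawn. For the measured compounds named here, the single measured step between close neighbours, a 1.1-fold lower number from compound 1 to compound 3 (0.05 log units; within the scatter), concerns a chloro in place of hydrogen and does not speak to the change considered next. Compound 4 `COc1ccc2cc(C(C)c3nnc4n3N=C(c3ccc([N+](=O)[O-])cc3)CS4)ccc2c1` differs from compound 2 by nitro in place of trifluoromethyl on an aromatic carbon. Going by the values given here, no measured pair in the set involves a nitro or a trifluoromethyl group, so the data give no ground for a shift in this assay beyond the scatter in either direction. The step expected is therefore a 1.1-fold lower number from compound 2 to compound 4 (0.03 log units; within the scatter), within the scatter. Compound 4 is estimated at 10000 nM, with a range from 4000 nM to 25000 nM.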

Compound 4, half-maximal inhibitory concentration: 15100 nM
The estimate for compound 4 lay 1.5-fold (0.18 log units) below the measured number, and the stated range covers the measured number.
By their numbers in this assay, from the lowest: compounds 3, 1, 2 and 4 (each within the scatter of the next, the first and the last beyond it).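

In this assay, for the compounds shown here, the change from 4-(trifluoromethyl)phenyl to 4-nitrophenyl gives a 1.4-fold higher number from compound 2 to compound 4 (0.15 log units; within the scatter), the first reading for an exchange of one group for another at this place on the aromatic ring, para to a large group. Nitro, which carries hydrogen-bond acceptors where trifluoromethyl carries none, therefore stands level with trifluoromethyl here, and the exchange shows no effect that can be told from the scatter. No measured property of these compounds bears on this result.

Open, on these data alone, is whether an amine or a carboxylic acid at this place would give a step beyond the scatter. Also open, as far as these compounds go, is whether nitro in place of trifluoromethyl would read the same with the other end of the molecule as in compound 1.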